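Methyl on the Outer Phenyl Ring in Two Related Series

A few compounds are considered here, and "the series" means these few. Any claim that something is new, unique, unknown or untested is made for them only; others in the source may bear on it.

Compound 1 `O=C(NNC(=S)Nc1csc(-c2ccccc2)c1)c1ccc(O)cc1` and compound 2 `Cc1ccc(-c2cc(NC(=S)NNC(=O)c3ccc(O)cc3)cs2)cc1` share one core, and compound 3 `COc1cc(OC)cc(C(=O)NNC(=S)Nc2csc(-c3ccccc3)c2)c1` and compound 4 `COc1cc(OC)cc(C(=O)NNC(=S)Nc2csc(-c3ccc(C)cc3)c2)c1` share another; the difference between the two cores is not broken down here. Three of the four compounds have been examined in a functional assay on MCF7 cells (Homo sapiens) for inhibition, read by colorimetric assay and MTT assay, with a stated time of 72 h; on this read-out lower numbers stand for stronger inhibition and higher numbers for weaker inhibition.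

In this assay compound 1 gives 78000 nM. In this assay compound 2 gives 42000 nM. The change from compound 1 to compound 2 is methyl in place of hydrogen on an aromatic carbon and it produced a 1.9-fold lower number from compound 1 to compound 2 (0.27 log units; within the scatter). In this assay compound 3 gives 38000 nM. The values of compound 3 and compound 2 lie within the scatter of each other, so no order can be read between them; against compound 1 the value of compound 3 is the lower of the two, and that gap lies beyond the scatter.

Compound 4 has not yet been measured. The change from compound 3 to compound 4 is methyl in place of hydrogen on an aromatic carbon, the same change that leads from compound 1 to compound 2, at the same kind of place on the same kind of ring. A step of about the same size is expected from compound 3 to compound 4, namely a 1.6-fold lower number from compound 3 to compound 4 (0.20 log units; within the scatter), because the same change earlier gave a 1.9-fold lower number from compound 1 to compound 2 (0.27 log units; within the scatter). On that basis compound 4 is expected to give 24000 nM in this assay, with a likely range from 10000 nM to 60000 nM.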

Compound 4, half-maximal inhibitory concentration: 26000 nM
Compound 4: the middle estimate sits 1.1-fold (0.03 log units) below what was measured, within the range that was stated.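

In this assay, the change from phenyl to 4-methylphenyl on the second core gave a 1.5-fold lower number from compound 3 to compound 4 (0.16 log units; within the scatter). Each of the two steps lies within the scatter when read alone, so neither shows on its own that the methyl group shifts the number on its core, and the pair cannot establish a real effect of this change; two cores are also too few to support a rule for the whole series. What the comparison does show is that the step on the second core agrees with the step on the first, so that the change carried across these two cores with no difference that can be told apart in this read-out: the same change on two cores in this assay, a 1.9-fold lower number (0.27 log units; within the scatter) from compound 1 to compound 2 and a 1.5-fold lower number (0.16 log units; within the scatter) from compound 3 to compound 4, 1.3-fold (0.10 log units) apart, within the scatter of two such steps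

The compounds shown carry only hydrogen or methyl at this place, which leaves open how an ethyl group, a methoxy group, a chlorine atom or an amine there would read, and whether any of these would give a step beyond the scatter. Also open, on these data alone, is whether the agreement between the two steps would hold on a third core.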